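The source may report more compounds than this note shows. Statements on the series, on what has been measured and on what is new or still open speak of the compounds shown alone.

Measured so far in an ADME assay on MT4 cells (Homo sapiens) for cytotoxicity, read by MTT assay; on this read-out higher numbers stand for lower toxicity in this test and lower numbers for higher toxicity in this test:
- compound 1 `Cc1ccc(C(=O)N(C(=S)OCCN2C(=O)c3ccccc3C2=O)c2ccc(Cl)cc2)cc1`: > 100000 nM (a limit of the assay)
- compound 2 `Cc1ccc(N(C(=O)c2ccccc2C)C(=S)OCCN2C(=O)c3ccccc3C2=O)cc1`: > 100000 nM (a limit of the assay)
- compound 3 `Cc1ccc(C(=O)N(C(=S)OCCN2C(=O)c3ccccc3C2=O)c2ccc(C)cc2)cc1`: 83000 nM

Compound 1 stands at the limit of > 100000 nM in this assay, at which 2 of the 3 values shown sit, so its position is known only as a limit. The next step leads to compound 4 `O=C1c2ccccc2C(=O)N1CCOC(=S)N(C(=O)c1cc(F)ccc1F)c1ccc(Cl)cc1`, which has 2,5-difluorophenyl in place of 4-methylphenyl on a carbonyl carbon. For the measured compounds named here, no measured compound carries the 2,5-difluorophenyl group.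

Going by the values given here, two measured steps bear on this change. The closer one is an at least 1.2-fold lower number from compound 2 to compound 3 (0.08 log units; that floor lies within the scatter), a change of group at the same carbonyl carbon. The other is an at least 1.2-fold lower number from compound 1 to compound 3 (0.08 log units; that floor lies within the scatter), made on an aromatic carbon elsewhere in the structure. Neither step is shown to exceed the scatter, so no step beyond the scatter is expected in this assay, and a reading at the limit is quite possible. The expected step is an at least 1.1-fold lower number from compound 1 to compound 4 (0.04 log units; that floor lies within the scatter). The estimate for compound 4 is 90000 nM, with an expected range from 35000 nM to 130000 nM.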

Compound 4, half-maximal cytotoxic concentration: 54000 nM
Compound 4: the middle estimate sits 1.7-fold (0.22 log units) above what was measured, within the range that was stated.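

In this assay, for the compounds shown here, the carbonyl carbon carries for the first time a ring other than a methylphenyl, and 2,5-difluorophenyl in place of 4-methylphenyl there gives an at least 1.8-fold lower number from compound 1 to compound 4 (0.26 log units; that floor lies within the scatter). The earlier steps at this carbon covered only 2-methylphenyl and 4-methylphenyl, so this is the first sign that a fluorinated ring at this place is compatible with a measured number, though the step is not shown to exceed the scatter. For compound 1 the value > 100000 nM is a limit of the assay, so only a floor can be given for this step: the limit of > 100000 nM in this assay, at which 2 of the 4 values shown sit.

Open, going by these compounds, is how a phenyl with a single fluorine, or a phenyl bearing an amine or a carboxylic acid, would read at this carbonyl carbon in this assay. Also open, on these data alone, is whether 2,5-difluorophenyl reads the same with methyl in place of chloro on the aromatic carbon.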